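This account rests on a few compounds, and the source may have more. Where it says the series, first, only, none or still open, it means among the compounds named here.

Compound 1 `Cc1nc(N(C)c2ccc([Se]C#N)c(C)c2)c2ccccc2n1` gives 8 nM
Compound 2 `Cc1nc(N(C)c2ccc([Se]C#N)c(Cl)c2)c2ccccc2n1` gives 7 nM
Compound 3 `C[Se]c1ccc(N(C)c2nc(C)nc3ccccc23)cc1Cl` gives 2 nM

In a functional assay on A549 cells (Homo sapiens) for inhibition, read by MTT assay, with a stated time of 48 h (on this read-out higher numbers stand for weaker inhibition and lower numbers for stronger inhibition), compound 2 gives 7 nM and cannot be told apart from compound 1, as a 1.1-fold lower number from compound 1 to compound 2 (0.06 log units; within the scatter) shows. Only compound 3 stands clearly apart, with a 3.5-fold lower number from compound 2 to compound 3 (0.54 log units; beyond the scatter). The next compound to consider is compound 4 `Cc1nc(N(C)c2ccc([Se]C#N)c(F)c2)c2ccccc2n1`, and the change leading to it is fluoro in place of chloro on an aromatic carbon. In words, this is fluoro in place of chloro on an aromatic carbon, while the rest of the molecule stays as it is.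

Two measured steps can be weighed here. The first, chloro in place of methyl, is made on the same aromatic carbon and amounts to a 1.1-fold lower number from compound 1 to compound 2 (0.06 log units; within the scatter). The second, methyl in place of cyano on a selenium, is larger but is made elsewhere in the molecule, so it says little about this swap. Among the compounds with values here, no compound measured so far carries fluoro, so the evidence is thin. Within the data shown here, still, the one change tried on this carbon left the number within the scatter, so no step beyond the scatter is expected in this assay. The expected result is a 1.1-fold higher number from compound 2 to compound 4 (0.06 log units; within the scatter). For compound 4 the estimated value is 8 nM, with an expected range from 3 nM to 20 nM.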

Compound 4, half-maximal inhibitory concentration: 4 nM
The estimate for compound 4 lay 2.0-fold (0.30 log units) above the measured number, within the range that was stated.
By their numbers in this assay, from the lowest: compounds 3, 4, 2 and 1 (each within the scatter of the next, the first and the last beyond it).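

In this assay this aromatic carbon has now carried methyl, chloro and fluoro, and the two new comparisons, a 1.8-fold lower number from compound 2 to compound 4 (0.24 log units; within the scatter) and a 2.0-fold lower number from compound 1 to compound 4 (0.30 log units; within the scatter), both stay within the scatter. Before this result, a single swap at this carbon could have been a chance exception, but three different groups now give numbers that cannot be told apart, so compounds 1, 2 and 4 cannot be put in any order. Within these three compounds, the carbon accepts a small halogen or a methyl without a clear change in the number, although no measurement shown here gives a reason for this.

From the compounds shown here alone, what remains open is whether that tolerance extends to larger or quite different groups on the same carbon, such as methoxy, an amine or a carboxylic acid, or to plain hydrogen. Within the data shown here, also open is whether fluoro on this carbon would keep the number unchanged once methyl replaces cyano on the selenium, the one change so far that moved a number beyond the scatter, as in a 3.5-fold lower number from compound 2 to compound 3 (0.54 log units; beyond the scatter).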